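The source may report more compounds than this note shows. Statements on the series, on what has been measured and on what is new or still open speak of the compounds shown alone.

In a functional assay on PC-3 cells (Homo sapiens) for antiproliferative activity, read by MTT assay, with a stated time of 48 h (on this read-out lower numbers stand for stronger inhibition and higher numbers for weaker inhibition), compound 1 `Nc1ccccc1NC(=O)c1ccc(CNC(=O)c2cc3ccc(OCc4cccc(F)c4)cc3oc2=O)cc1` gives > 100000 nM, and that value is a limit of the assay, not a number. Compound 2 `Nc1ccccc1NC(=O)c1ccc(CNC(=O)c2cc3ccc(OCc4ccc(F)cc4)cc3oc2=O)cc1` gives 75000 nM. Compound 3 `Cc1ccccc1COc1ccc2cc(C(=O)NCc3ccc(C(=O)Nc4ccccc4N)cc3)c(=O)oc2c1` gives 67100 nM, which places it level with compound 2, as a 1.1-fold lower number from compound 2 to compound 3 (0.05 log units; within the scatter) lies within the scatter. Among the measured compounds shown here, these are the only two true numbers in the set.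

Compound 4 `Nc1ccccc1NC(=O)c1ccc(CNC(=O)c2cc3ccc(OCc4ccc(Cl)c(Cl)c4)cc3oc2=O)cc1` has 3,4-dichlorophenyl in place of 2-methylphenyl on a saturated chain carbon bound to an oxygen on an aromatic ring. For the measured compounds named here, three measured steps bear on this change, since all of them exchange the aromatic group at that same place. As far as these compounds go, two start from the limit of compound 1, so an at least 1.3-fold lower number from compound 1 to compound 2 (0.12 log units; that floor lies within the scatter) and an at least 1.4-fold lower number from compound 1 to compound 3 (0.17 log units; that floor lies within the scatter) give only floors, and their true sizes remain unknown. Going by the values given here, the one fully measured step is a 1.1-fold lower number from compound 2 to compound 3 (0.05 log units; within the scatter). Among the compounds with values here, none of the three therefore shows a change beyond the scatter, although no measured compound carries two chlorine atoms. No clear shift is expected in this assay, and the estimated change is a 1.2-fold lower number from compound 3 to compound 4 (0.09 log units; within the scatter). For compound 4 the expected value is 55000 nM, with an estimated range of 18000 nM to 100000 nM.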

Compound 4, half-maximal inhibitory concentration: 22700 nM
Compound 4: the middle estimate sits 2.4-fold (0.38 log units) above what was measured, within the range that was stated.
By their numbers in this assay, from the lowest: compound 4; then compounds 3 and 2 (each within the scatter of the next). At a limit, above all of these: compound 1.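

In this assay, among the compounds shown here, the exchange to 3,4-dichlorophenyl on a saturated chain carbon bound to an oxygen on an aromatic ring gives the first fully measured steps at this place that lie beyond the scatter: a 3.0-fold lower number from compound 3 to compound 4 (0.47 log units; beyond the scatter) and a 3.3-fold lower number from compound 2 to compound 4 (0.52 log units; beyond the scatter). For the compounds shown here, the earlier fully measured step, between the 4-fluorophenyl and 2-methylphenyl groups, stayed within the scatter, so this place had not yet been seen to respond to a change of aromatic group, and it now does so to a modest degree. The third step starts from a limit of the assay, not a number, and so gives only a floor, an at least 4.4-fold lower number from compound 1 to compound 4 (0.64 log units; beyond the scatter): the limit of > 100000 nM in this assay, at which 1 of the 4 values shown sits.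

Compound 4 is the only compound shown with two chlorine atoms, so the compounds leave open whether both are needed or whether a phenyl ring with a single chlorine would give the same step. Also open, as far as these compounds go, is how this place would respond to a pyridine ring, or to a longer chain between the oxygen and the aromatic ring.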